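Trading Two Methoxy Groups for a Bare Phenyl Ring

The source may hold more compounds than are shown below. What is called first, only, known or untested is meant among the compounds shown, and "the series" means these compounds.

Compound 1 `COc1ccc(C(=O)NC(=S)Nc2cccc(-c3nc4ccccc4[nH]3)c2)cc1OC` carries a 3,4-dimethoxyphenyl group on its carbonyl carbon. In a functional assay on MDA-MB-231 cells (Homo sapiens) for inhibition, read by colorimetric assay and crystal violet staining, with a stated time of 72 h (a lower number here means a stronger inhibitor, a higher number a weaker inhibitor), compound 1 gives 10000 nM, the highest of the two numbers available. Compound 2 `Cc1ccc(-c2nc3ccccc3[nH]2)cc1NC(=S)NC(=O)c1ccc2c(c1)OCCO2`, built on a related thiourea core, gives 500 nM in this assay, and compound 3 `CCOc1ccc(C(=O)NC(=S)Nc2cc(-c3nc4ccccc4[nH]3)ccc2C)cc1OCC` stands at "not determined" (no result reported). Compound 4 `O=C(NC(=S)Nc1cccc(-c2nc3ccccc3[nH]2)c1)c1ccccc1` differs from compound 1 in one place: phenyl in place of 3,4-dimethoxyphenyl on a carbonyl carbon. Going by the values given here, no measured pair shows this exact change, so its effect is uncertain; a modest move toward a lower number seems plausible, though a step within the scatter is also possible. The expected step of a 1.7-fold lower number from compound 1 to compound 4 (0.22 log units; within the scatter) points that way. Compound 4 is expected near 6000 nM, within a range from 1500 nM to 20000 nM.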

Compound 4, half-maximal inhibitory concentration: > 10000 nM
Compound 4: a limit, no number; the forecaster's own chance of this, stated with the estimate: 25%; at least 1.6-fold (0.22 log units) between middle value and limit.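

Placing phenyl where 3,4-dimethoxyphenyl stood on the carbonyl carbon gives a number no lower from compound 1 to compound 4 (the limit leaves the size open) in this assay. Going by these compounds alone, this is the first direct comparison at this position, and it shows that the bare phenyl ring brings no gain in this assay. The result for compound 4 is a limit, not a number: the limit of > 10000 nM in this assay, at which 1 of the 4 values shown sits.

As far as these compounds go, how far compound 4 actually lies from compound 1 stays open. So does whether a phenyl ring carrying an amine or a carboxylic acid at this position would give a lower number.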